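The source may report more compounds than this note shows. Statements on the series, on what has been measured and on what is new or still open speak of the compounds shown alone.

Compound 1 `COc1ccc(COCNc2n[n+]([O-])c3ccccc3[n+]2[O-])cc1` carries a 4-methoxyphenyl on a saturated chain carbon bound to an oxygen on a saturated carbon. Among the compounds with values here, in a functional assay on PC-3 cells (Homo sapiens) for cytotoxicity, read by MTT assay, with a stated time of 72 h (on this read-out higher numbers stand for weaker inhibition and lower numbers for stronger inhibition), compound 1 gives 52800 nM, the highest of the two numbers measured so far. Compound 2 `CCCCCCCOCNc1n[n+]([O-])c2ccccc2[n+]1[O-]` differs from it by hexyl in place of 4-methoxyphenyl on a saturated chain carbon bound to an oxygen on a saturated carbon; in this assay compound 2 gives 390 nM, and the step is a 140-fold lower number from compound 1 to compound 2 (2.13 log units; beyond the scatter). Compound 3 `CCCCCOCNc1n[n+]([O-])c2ccccc2[n+]1[O-]` is the next member of the series: butyl in place of 4-methoxyphenyl on a saturated chain carbon bound to an oxygen on a saturated carbon. Within the data shown here, the only measured step that bears on it is a 140-fold lower number from compound 1 to compound 2 (2.13 log units; beyond the scatter), which exchanged the same 4-methoxyphenyl for a longer chain at the same place. Butyl is shorter than hexyl, so the move to compound 3 is expected to run in the same direction, downward, although it is uncertain whether the full size of that earlier step carries over to the shorter chain. The step expected for compound 3 is an 18-fold lower number from compound 1 to compound 3 (1.25 log units; beyond the scatter), which puts the estimate at 3000 nM in this assay, with a range from 700 nM to 13000 nM.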

Compound 3, half-maximal inhibitory concentration: 8510 nM
Beside the measured number, compound 3's estimate is 2.8-fold (0.45 log units) below it; low and high end bracket the measured number.
By their numbers in this assay, from the lowest: compound 2; then compound 3; then compound 1.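

In this assay, the step with butyl in place of 4-methoxyphenyl is a 6.2-fold lower number from compound 1 to compound 3 (0.79 log units; beyond the scatter) and lies beyond the scatter, so the downward move at this position is not confined to the hexyl of compound 2. Compound 3 also shows that the chain's length matters at this position: with hydrogen in place of ethyl at the chain's far end, the step is a 22-fold higher number from compound 2 to compound 3 (1.34 log units; beyond the scatter) and is classed as large, whereas the step from the 4-methoxyphenyl to butyl is classed as modest. Exchanging the 4-methoxyphenyl for an open chain therefore does not by itself fix the number, which differs widely between the butyl and hexyl compounds, and nothing given here explains either step.

On these data alone, with only butyl and hexyl among the chains, it remains open whether a longer chain would lower the number further, level off or reverse the trend, and whether a branched chain or a chain ending in an amine or a carboxylic acid would fit the same picture. An unsubstituted phenyl would be needed to show how much of the high number of compound 1 goes with the methoxy group and how much with the aromatic ring itself.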